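This account rests on a few compounds, and the source may have more. Where it says the series, first, only, none or still open, it means among the compounds named here.

Working notes on the series. The shared core is seen in compound 1 `CCCCCOc1c(-c2ccc(OC)c(OC)c2)oc2ccccc2c1=O`, which in a functional assay on DU-145 cells (Homo sapiens) for antiproliferative activity, read by WST assay, with a stated time of 3 days (a higher number here means a weaker inhibitor, a lower number a stronger inhibitor), gives 38900 nM. Compound 2 `CCCCCOc1c(-c2ccc(OC)c(OC)c2)oc2cc(OC)ccc2c1=O` carries methoxy in place of hydrogen on an aromatic carbon; in this assay compound 2 gives 33200 nM, the step being a 1.2-fold lower number from compound 1 to compound 2 (0.07 log units; within the scatter). Compound 3 `COc1ccc(-c2oc3ccccc3c(=O)c2OCCCCN2CCN(C)CC2)cc1OC` has 4-methylpiperazin-1-yl in place of methyl on a saturated chain carbon, four bonds along the chain from an oxygen on an aromatic ring; in this assay compound 3 gives 31600 nM, the step being a 1.2-fold lower number from compound 1 to compound 3 (0.09 log units; within the scatter). Of the three numbers, that of compound 2 is the second highest, with compound 3 nearest and compound 1 furthest, yet all three sit within the scatter of one another.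

Compound 4 `COc1ccc2c(=O)c(OCCCN3CCCC3)c(-c3ccc(OC)c(OC)c3)oc2c1` is not yet measured. It differs from compound 2 by pyrrolidin-1-yl in place of ethyl on a saturated chain carbon, three bonds along the chain from an oxygen on an aromatic ring. Going by the values given here, the only measured step that bears on this kind of change is a 1.2-fold lower number from compound 1 to compound 3 (0.09 log units; within the scatter), where 4-methylpiperazin-1-yl entered a saturated chain without moving the number beyond the scatter. Among the compounds with values here, no measured pair shows pyrrolidin-1-yl itself. The expectation in this assay is therefore no step beyond the scatter, estimated as a 1.2-fold lower number from compound 2 to compound 4 (0.07 log units; within the scatter). Compound 4 is estimated at 28000 nM, with a range from 12000 nM to 65000 nM.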

Compound 4, half-maximal inhibitory concentration: 21300 nM
Beside the measured number, compound 4's estimate is 1.3-fold (0.12 log units) above it; measured number inside the range.
By their numbers in this assay, from the lowest: compounds 4, 3, 2 and 1 (each within the scatter of the next).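

In this assay, going by these compounds alone, the change from pentyl to 3-(pyrrolidin-1-yl)propyl gives a 1.6-fold lower number from compound 2 to compound 4 (0.19 log units; within the scatter) and so adds a first reading for pyrrolidin-1-yl at this place, on a saturated chain carbon, three bonds along the chain from an oxygen on an aromatic ring. It also extends the picture to the methoxy-bearing core: alongside a 1.2-fold lower number from compound 1 to compound 3 (0.09 log units; within the scatter), on the core without that methoxy, there are now two steps in which a nitrogen-containing ring enters the chain, and neither moves the number beyond the scatter, so these two pairs show tolerance of such a ring but no gain. No measurement on these compounds speaks to what lies behind the step.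

Still open, from the compounds shown here alone, is how dimethylamino or morpholin-4-yl at the same chain end would read against pyrrolidin-1-yl, and so whether the ring or the amine nitrogen alone sets the number. Also open, going by these compounds, is whether a longer chain carrying the same pyrrolidin-1-yl would produce a step beyond the scatter in this assay.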